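Swapping one benzyl group for another in a cytotoxicity screen

The source may hold more compounds than are shown below. What is called first, only, known or untested is meant among the compounds shown, and "the series" means these compounds.

Measured compounds:
compound 1 `Cn1c(SCc2ccc(Cl)c(Cl)c2)nnc1-c1cc([N+](=O)[O-])cc([N+](=O)[O-])c1` — > 30000 nM
compound 2 `COc1ccc(CSc2nnc(-c3cc([N+](=O)[O-])cc([N+](=O)[O-])c3)n2Cc2ccccc2)cc1` — > 30000 nM

In an ADME assay on HepG2 cells (Homo sapiens) for cytotoxicity, with a stated time of 48 h (a higher number here means a weaker inhibitor, a lower number a stronger inhibitor), compound 1 gives > 30000 nM, which is a limit of the assay and not a number. Compound 2 gives > 30000 nM in this assay, and this too is a limit rather than a number. For the measured compounds named here, compound 2 thus stands at the limit of > 30000 nM in this assay, at which 2 of the 2 values shown sit; nothing in the two values shown separates it from compound 1, and no step between measured compounds is available to calibrate the change that follows.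

Compound 3 `O=[N+]([O-])c1cc(-c2nnc(SCc3ccc(Cl)c(Cl)c3)n2Cc2ccccc2)cc([N+](=O)[O-])c1` is the unmeasured partner of compound 2. It differs from compound 2 by 3,4-dichlorophenyl in place of 4-methoxyphenyl on a saturated chain carbon bound to a sulfur. Compound 1, which carries the same 3,4-dichlorophenyl on a saturated chain carbon bound to a sulfur, gives > 30000 nM, a limit. On that basis the author expects no step beyond the scatter in this assay, with the expected step being a step that the limit leaves unreadable from compound 2 to compound 3. Compound 3 is accordingly estimated at 40000 nM in this assay, within a range of 20000 nM to 100000 nM, and most likely reported again only as a limit.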

Compound 3, half-maximal inhibitory concentration: > 30000 nM
Compound 3 gave a limit, no number; the forecaster's own chance of this, stated with the estimate: 85%; the middle value lies beyond the limit too.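

In this assay compound 3 gives > 30000 nM as a limit and not a number. The steps to compound 3 from compound 1 and from compound 2 cannot be read. The compounds shown leave open whether 3,4-dichlorophenyl in place of 4-methoxyphenyl makes any difference to cytotoxicity beyond the limit of this assay.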